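Half-life at the limit: methylcarbamoyl to carbamoyl

The source may hold more compounds than are shown below. What is called first, only, known or untested is meant among the compounds shown, and "the series" means these compounds.

Measured in an in vitro ADME assay on microsomes from liver (Homo sapiens) for metabolic stability, tested at 1 uM; on this read-out higher numbers stand for a longer-lived compound and lower numbers for a shorter-lived compound:
Compound 1 `CS(=O)(=O)c1ccc(-c2cnc(N)c(-c3ccc(C#N)cc3)c2)cc1`: > 5.83 h
Compound 2 `CNC(=O)c1ccc(-c2cc(-c3ccc(S(C)(=O)=O)cc3)cnc2N)cc1`: > 5.83 h

Both entries are limits of the assay and not numbers: the limit of > 5.83 h in this assay, at which 2 of the 2 values shown sit. In this assay compound 2 gives > 5.83 h, which is a limit, so its position is only bounded on one side.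

Compound 3 `CS(=O)(=O)c1ccc(-c2cnc(N)c(-c3ccc(C(N)=O)cc3)c2)cc1` is not yet measured. It differs from compound 2 by hydrogen in place of methyl on an amide-type nitrogen. Among the compounds with values here, the one measured step that bears on this is a step that the two limits leave unreadable from compound 1 to compound 2, methylcarbamoyl in place of cyano on an aromatic carbon, and it supplies no size. With no readable size to carry over, a step that the limit leaves unreadable from compound 2 to compound 3 is expected to stay within the usual scatter, with no direction foreseen. For compound 3 the estimated half-life is 6 h, with an expected range of 3 h to 12 h.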

Compound 3, half-life in the Homo sapiens assay: > 5.83 h
Compound 3: no number, only a limit; the forecaster's own chance of this, stated with the estimate: 70%; the middle value is on the limit's open side.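

In the Homo sapiens assay compound 3 gives > 5.83 h, which is a limit and not a number. Within the data shown here, in the Homo sapiens assay no step among compound 1, compound 2 and compound 3 can be read: the limit of > 5.83 h in the Homo sapiens assay, at which 3 of the 3 values shown sit. The compounds shown leave open how far each half-life extends past this limit and whether the nitrile, methylcarbamoyl and carbamoyl compounds differ at all. In a physicochemical assay for lipophilicity, read by HPLC, at pH 7.4 (on this read-out higher numbers stand for higher lipophilicity and lower numbers for lower lipophilicity), compound 2 gives 1.7 and compound 3 gives 1.5, two values within the usual scatter of each other.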